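Adding a second chloro to the benzyl ring of compound 2

A few compounds are considered here, and "the series" means these few. Any claim that something is new, unique, unknown or untested is made for them only; others in the source may bear on it.

Measured compounds:
Compound 1, `O=C(O)Cn1c(SCc2cccc(Cl)c2)nc2ccccc21`, 186 nM
Compound 2, `O=C(O)Cn1c(SCc2ccccc2Cl)nc2ccccc21`, 370 nM
Compound 3, `O=C(O)Cn1c(SCc2ccccc2Br)nc2ccccc21`, 580 nM

In an assay on HEK293 cells for displacement of a labelled ligand from prostaglandin D2 receptor 2 (Homo sapiens) (on this read-out lower numbers stand for stronger inhibition and higher numbers for weaker inhibition), compound 2 stands second highest of the three numbers. Its nearest neighbour is compound 3, and the difference a 1.6-fold higher number from compound 2 to compound 3 (0.20 log units; within the scatter) is within the scatter. The step of a 2.0-fold higher number from compound 1 to compound 2 (0.30 log units; within the scatter) is also within the scatter, so on these numbers compound 2 and compound 1 cannot be ordered with confidence.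

Compound 4, `O=C(O)Cn1c(SCc2cc(Cl)ccc2Cl)nc2ccccc21`, is not yet measured. It differs from compound 2 by chloro in place of hydrogen on an aromatic carbon. The benzyl ring of compound 4 therefore carries two chloro groups where compound 2 carries one.

Among the measured compounds shown here, two measured steps bear on the question. The step of a 2.0-fold higher number from compound 1 to compound 2 (0.30 log units; within the scatter) shows that moving the single chloro from the 3-position to the 2-position of the phenyl changes the number only within the scatter. The step of a 1.6-fold higher number from compound 2 to compound 3 (0.20 log units; within the scatter) shows that exchanging chloro for bromo at that 2-position also stays within the scatter. For the measured compounds named here, no measured pair shows the effect of having two halogens on the ring at once, so the expectation rests on these small single-halogen steps. The expected step of a 1.5-fold lower number from compound 2 to compound 4 (0.17 log units; within the scatter) is small, leaning towards a lower number because compound 1 with its 3-chlorophenyl gives 186 nM. Compound 4 is estimated at 250 nM, with a range from 100 nM to 650 nM.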

Compound 4, half-maximal inhibitory concentration: 470 nM
Compound 4: middle estimate off by 1.9-fold (0.27 log units), on the low side; the range from low to high includes it.
By their numbers in this assay, from the lowest: compounds 1, 2, 4 and 3 (each within the scatter of the next, the first and the last beyond it).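

In this assay, a chloro placed on the aromatic carbon that is para to the chloro group of compound 2 and meta to a large group gives a 1.3-fold higher number from compound 2 to compound 4 (0.10 log units; within the scatter), so on these numbers a second halogen at this place brings no change that can be claimed. Added to the other single-chloro ring, a chloro gives a 2.5-fold higher number from compound 1 to compound 4 (0.40 log units; beyond the scatter), a modest step beyond the scatter, so the same two-chloro ring cannot be told apart from one single-chloro compound but stands apart from the other. No supporting evidence is available to explain either step.

The compounds shown leave open whether a fluoro, methoxy or trifluoromethyl group on this same ring carbon would read like the chloro, since only chloro and bromo appear on the ring here. They also leave open whether a longer chain between the sulfur and the ring, or an amine on the ring, would alter how much a second substituent matters in this assay.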